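This account rests on a few compounds, and the source may have more. Where it says the series, first, only, none or still open, it means among the compounds named here.

In a functional assay on MT4 cells (Homo sapiens) for cytotoxicity (a higher number here means a weaker inhibitor, a lower number a stronger inhibitor), compound 1 `Cc1ccc(Sc2cccc(N)c2C#N)cc1` reaches only a limit, > 200000 nM. Compound 2 `N#Cc1ccc(Sc2cccc(N)c2C#N)cc1` is also held at a limit, > 200000 nM. Compound 3 `CCOc1cc(C)cc(S(=O)(=O)c2cccc(N)c2C#N)c1`, at 9000 nM, is the only one of the three with a true number. Compound 4 `Cc1cc(Cl)cc(S(=O)(=O)c2cccc(N)c2C#N)c1` puts chloro in place of ethoxy on an aromatic carbon, meta to a methyl group: chloro in place of ethoxy on an aromatic carbon. Within the data shown here, the one measured step, a step that the two limits leave unreadable from compound 1 to compound 2, involves a different exchange and gives no size to carry over. Among the measured compounds shown here, no measured step therefore bears directly on this change, and no direction can be favoured, so a shift beyond the scatter is not expected. The expected outcome is a 1.1-fold higher number from compound 3 to compound 4 (0.05 log units; within the scatter). Compound 4 is estimated at 10000 nM, with an expected range of 3000 nM to 40000 nM.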

Compound 4, half-maximal inhibitory concentration: > 200000 nM
Compound 4 ended at the assay's limit; the forecaster's own chance of this, stated with the estimate: 15%; middle value at least 20-fold (1.30 log units) away from the limit.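

In this assay, among these compounds, the aromatic carbon meta to a methyl group turns out to matter: chloro in place of ethoxy gives an at least 22-fold higher number from compound 3 to compound 4 (1.34 log units; beyond the scatter) in a sulfone pair, which the earlier compounds could not show, as their one step was unreadable and involved a different exchange. Compound 4 sits at a limit, so this step gives a lower bound and not a full size: the limit of > 200000 nM in this assay, at which 3 of the 4 values shown sit.

The compounds shown leave open whether a methoxy group, a longer alkoxy chain or an amine at this position would keep a true number as ethoxy does.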